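Working notes: from acetyl to 2-methoxyethyl on the shared core

This account rests on a few compounds, and the source may have more. Where it says the series, first, only, none or still open, it means among the compounds named here.

Compound 1 `CC(=O)C1=C(N2CC2)C(=O)C(C)=C(N2CC2)C1=O` is the weakest of the three compounds measured in a functional assay on L1210 cells (Mus musculus), with a stated time of 1 days (a lower number here means a less potent compound, a higher number a more potent compound, by a factor of ten per unit of this negative logarithm), where compound 1 gives 3.94. Compound 3 `CC(C)C1=C(N2CC2)C(=O)C=C(N2CC2)C1=O` gives 5.16 in this assay, and compound 2 `CCC1=C(N2CC2)C(=O)C(CCOC(N)=O)=C(N2CC2)C1=O` gives 5.98; both stand beyond the scatter above compound 1. Compound 4 `COCCC1=C(N2CC2)C(=O)C(C)=C(N2CC2)C1=O` is not yet measured. It differs from compound 1 by 2-methoxyethyl in place of acetyl on a double-bonded ring carbon. Among the compounds with values here, no measured pair shows this exact change. The two compounds without an acetyl group on the core, compound 2 with 5.98 and compound 3 with 5.16, both run higher than compound 1, so a gain is expected for compound 4 in this assay. The step of a number 1.36 log units higher from compound 1 to compound 4 (beyond the scatter) is expected to be clearly beyond the scatter. Compound 4 is estimated at 5.3, in a range from 4.5 to 6.1.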

Compound 4, logarithm of the reciprocal of the active concentration, log(1/C): 5.19
Estimate against measurement, compound 4: 0.11 log units above; measured number inside the range.
By their numbers in this assay, from the lowest: compound 1; then compounds 3 and 4 (each within the scatter of the next); then compound 2.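

With the methyl group and both aziridin-1-yl groups unchanged, 2-methoxyethyl in place of acetyl on a double-bonded ring carbon gives a number 1.25 log units higher from compound 1 to compound 4 (beyond the scatter) in this assay. Within the data shown here, this pair is the only direct reading of a single change at this position, and it shows that the position tolerates a large shift in the number. Nothing available accounts for the step. Open, on these data alone, is whether removing the acetyl group or adding the 2-methoxyethyl group drives it. Also open, as far as these compounds go, is how a primary amine, a carboxylic acid or a longer ether chain would read on this ring carbon.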